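The compounds below may be only part of what the source reports. "The series", "measured", "known", "first", "only" and "open" are said of these compounds alone.

Compound 1 `Cc1nc2c(CCc3ccccc3)cccn2c1N`: 9 mg/kg
Compound 2 `Cc1nc2c(/C=C\c3ccccc3)cccn2c1N`: 23 mg/kg
Compound 3 `Cc1nc2c(/C=C/c3ccccc3)cccn2c1N`: 13 mg/kg

All three were examined in a functional assay on the whole organism for inhibition, with Rattus norvegicus as the target, with a stated time of 1 h; on this read-out lower numbers stand for an effect already at smaller amounts and higher numbers for an effect only at larger amounts of compound. Compound 2 lies within the scatter of compound 3, a 1.8-fold lower number from compound 2 to compound 3 (0.25 log units; within the scatter), the two being related by the fact that compounds 2 and 3 differ only in the configuration as drawn. Compound 1 gives a lower number than compound 2, and that gap is beyond the scatter.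

Compound 4 `CCc1c(C)nc2c(/C=C\c3ccccc3)cccn12` differs from compound 2 by ethyl in place of amino on an aromatic carbon. Within the data shown here, no measured pair covers this exchange: the only measured step, a 1.8-fold lower number from compound 2 to compound 3 (0.25 log units; within the scatter), concerns the drawing of a double bond, not the amino group, so it gives no guide to the size or direction of the coming step. The expectation for compound 4 therefore rests on compound 2 alone and is set near it with a wide range: in this assay compound 4 is estimated at 30 mg/kg, between 9 mg/kg and 100 mg/kg, which would mean an expected step of a 1.3-fold higher number from compound 2 to compound 4 (0.12 log units; within the scatter).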

Compound 4, dose for half-maximal effect: 0.8 mg/kg
Compound 4: the middle estimate sits 38-fold (1.57 log units) above what was measured; measured number outside the range, below it.
By their numbers in this assay, from the lowest: compound 4; then compounds 1, 3 and 2 (each within the scatter of the next, the first and the last beyond it).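

In this assay, among these compounds, the group on this aromatic carbon of the five-membered ring makes a large difference: ethyl in place of amino gives a 29-fold lower number from compound 2 to compound 4 (1.46 log units; beyond the scatter), a step far beyond anything the earlier compounds showed. On the core of compound 2, then, the amino group is not needed for the effect, and a group with no hydrogen-bond donor or acceptor serves much better. What lies behind this step cannot be told from what is known here.

As far as these compounds go, whether propyl or a carboxylic acid at this place would lower the number further stays open. So does whether ethyl brings a similar step on the cores of compound 1 and compound 3.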